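The source may report more compounds than this note shows. Statements on the series, on what has been measured and on what is new or still open speak of the compounds shown alone.

Compound 1 `O=c1[nH]c(=O)n([C@H]2C[C@@H]3O[PH](O)(O)OC[C@H]3O2)cc1F` gives 19 ug/mL in a functional assay on Raji cells (Homo sapiens) for antiproliferative activity; a lower number here means a stronger inhibitor, a higher number a weaker inhibitor. Compound 2 `O=c1[nH]c(=O)n([C@H]2C[C@@H]3O[PH](O)(O)OC[C@H]3O2)cc1Cl` reaches only the limit of this assay, > 1000 ug/mL, and no number is known for it. That places compound 2 at the limit of > 1000 ug/mL in this assay, at which 1 of the 2 values shown sits. Among the measured compounds shown here, the single measured step bearing on the series is an at least 52-fold higher number from compound 1 to compound 2 (1.72 log units; beyond the scatter), a large loss that stands beyond the scatter.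

Compound 3 `O=c1[nH]c(=O)n([C@H]2C[C@@H]3O[PH](O)(O)OC[C@H]3O2)cc1C(F)(F)F` differs from compound 2 by trifluoromethyl in place of chloro on an aromatic carbon. For the measured compounds named here, no measured pair shows what the trifluoromethyl group does here; the only guide is the step from fluoro to chloro, which ran toward the limit and left compound 2 without a number. On that basis compound 3 is expected to sit at or near the same limit, so that the step of a number no higher from compound 2 to compound 3 (the limit leaves the size open) is expected to be small or not resolvable. Compound 3 is therefore estimated at 1000 ug/mL, within a range from 200 ug/mL to 3000 ug/mL.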

Compound 3, concentration for 50% inhibition: >= 500 ug/mL
Compound 3: only a limit was reported; the forecaster's own chance of this, stated with the estimate: 75%; the middle value does not contradict the limit.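

Replacing fluoro with trifluoromethyl at this position also brings a large loss, with an at least 26-fold higher number from compound 1 to compound 3 (1.42 log units; beyond the scatter), so the loss is not confined to the change to chloro. Compound 3, like compound 2, carries only a limit in this assay: the limit of >= 500 ug/mL in this assay, at which 1 of the 3 values shown sits. The step between these two compounds cannot be read, which leaves chloro and trifluoromethyl unranked against each other.

Fluoro remains the only group shown here with a true number, and it is open whether a hydrogen, a methyl group or an amine at this position would also give one. Also open, going by these compounds, is where the true values of compound 2 and compound 3 lie, and whether these two compounds differ at all.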